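Swapping the sulfur-linked heteroaryl group on a thiazolylidene hydrazide

The source may hold more compounds than are shown below. What is called first, only, known or untested is meant among the compounds shown, and "the series" means these compounds.

Measured so far:
- compound 1, `O=C(CSc1nnnn1-c1ccccc1)N/N=c1/scc(-c2ccc(Br)cc2)n1-c1ccccc1`: 58.6%
- compound 2, `O=C(CSc1nnnn1-c1ccccc1)N/N=c1/scc(-c2ccc(F)cc2)n1-c1ccccc1`: 60%

Both compounds were tested in a functional assay on C6 cells (Rattus norvegicus) for cytotoxicity, read by MTT assay, with a stated time of 24 h, tested at 12 ug/mL; on this read-out higher numbers stand for a weaker effect at the one concentration tested and lower numbers for a stronger effect. Compound 1 gives the lowest of the two numbers, and its nearest neighbour is compound 2, which is a number 1.4 percentage points higher from compound 1 to compound 2 (within the scatter). Within the data shown here, the only structural change among the measured compounds is therefore the exchange of one halogen for another on an aromatic carbon, and that exchange left the read-out unchanged beyond the usual scatter.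

The next compound, compound 3, `O=C(CSc1ncccn1)N/N=c1/scc(-c2ccc(Br)cc2)n1-c1ccccc1`, keeps the bromo-bearing aryl group of compound 1 and differs from it elsewhere: pyrimidin-2-yl in place of 1-phenyl-1H-tetrazol-5-yl on a sulfur. Among the measured compounds shown here, no measured step involves a change on the sulfur, so the one step on hand, from the bromo to the fluoro compound, gives no guidance on how the read-out will move here. With nothing to point in either direction, the number for compound 3 is expected to stay near that of compound 1, with a wide allowance for uncertainty; the expected step is a number 0.6 percentage points lower from compound 1 to compound 3 (within the scatter). The estimate for compound 3 in this assay is 58%, with a range from 42% to 74%.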

Compound 3, a percentage reported as activity, at one concentration (the size of the read-out at that concentration, not a potency): 72.1%
Compound 3: middle estimate off by 14.1 percentage points, on the low side; measured number inside the range.
By their numbers in this assay, from the lowest: compounds 1 and 2 (each within the scatter of the next); then compound 3.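

The group on the sulfur turns out to matter in this assay: pyrimidin-2-yl in place of 1-phenyl-1H-tetrazol-5-yl gives a number 13.5 percentage points higher from compound 1 to compound 3 (beyond the scatter) and, on this read-out, a higher number means a weaker effect at the one concentration tested. Among these compounds, the halogen exchange gave only a number 1.4 percentage points higher from compound 1 to compound 2 (within the scatter) so the sulfur substituent is the first place in this small set where a change moves the number beyond the usual scatter. The group that leaves holds two aromatic rings and more heavy atoms than the single ring that enters, so several things change at once, and no measurement here says which of them lies behind the step.

Going by these compounds, it remains open whether a single ring of carbon only, such as phenyl, or a chain ending in an amine or a carboxylic acid on the same sulfur would give a number closer to compound 1 or to compound 3. Also open, on these data alone, is whether fluoro in place of bromo would stay as quiet with pyrimidin-2-yl on the sulfur, and how any of these numbers would look at other concentrations.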